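Moving from 2-fluorophenyl to 4-chlorophenyl on a shared core

The compounds below may be only part of what the source reports. "The series", "measured", "known", "first", "only" and "open" are said of these compounds alone.

Measured in an ADME assay on Vero 76 cells (Chlorocebus sabaeus) for cytotoxicity, read by MTT assay, with a stated time of 96 h; a lower number here means that less compound is tolerated, a higher number that more compound is tolerated:
- compound 1 `NS(=O)(=O)c1ccc(N2N=C(c3ccc(Oc4ccccc4)cc3)CC2c2ccccc2)cc1`: 85000 nM
- compound 2 `NS(=O)(=O)c1ccc(N2N=C(c3ccc(Oc4ccccc4)cc3)CC2c2ccccc2F)cc1`: 96000 nM

Compound 2 stands level with compound 1 on these numbers, since the gap between them lies within the scatter. The next structure, compound 3 `NS(=O)(=O)c1ccc(N2N=C(c3ccc(Oc4ccccc4)cc3)CC2c2ccc(Cl)cc2)cc1`, carries 4-chlorophenyl in place of 2-fluorophenyl on a saturated ring carbon. Among the measured compounds shown here, only one measured step bears on this change: fluoro in place of hydrogen on an aromatic carbon gave a 1.1-fold higher number from compound 1 to compound 2 (0.05 log units; within the scatter). For the measured compounds named here, no measured compound carries chlorine, so that step is only a loose guide. Going by that small step, no change beyond the scatter is expected in this assay, and no direction can be favoured. The estimate is therefore a 1.1-fold lower number from compound 2 to compound 3 (0.05 log units; within the scatter). For compound 3 the expected value is 85000 nM, with an estimated range from 45000 nM to 130000 nM.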

Compound 3, half-maximal cytotoxic concentration: 88000 nM
Compound 3: the middle estimate sits 1.0-fold (0.02 log units) below what was measured; measured number inside the range.
By their numbers in this assay, from the lowest: compounds 1, 3 and 2 (each within the scatter of the next).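

In this assay, 4-chlorophenyl in place of 2-fluorophenyl on the saturated ring carbon leaves the number level (a 1.1-fold lower number from compound 2 to compound 3 (0.04 log units; within the scatter)), and the same holds when 4-chlorophenyl takes the place of the unsubstituted phenyl (a 1.0-fold higher number from compound 1 to compound 3 (0.02 log units; within the scatter)). The phenyl on this carbon has now carried a fluoro group as 2-fluorophenyl and a chloro group as 4-chlorophenyl, and all three compounds remain level within the scatter. Nothing available here explains why these changes leave the number level.

On these data alone, whether an amine or a carboxylic acid on this phenyl, or a longer chain in its place, would move the number beyond the scatter stays open. Also open, as far as these compounds go, is whether a bromo group or a second chloro group on the same phenyl would stay level with these three compounds.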